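Benzodioxin in place of ethoxyphenyl, tested for cytotoxicity

A few compounds are considered here, and "the series" means these few. Any claim that something is new, unique, unknown or untested is made for them only; others in the source may bear on it.

Compound 1 `CCOC(=O)CCCCCOc1cccc(CN(C(=O)c2ccc(-c3cccc(-c4ccccc4)c3)cc2)C(C)C)c1`, compound 2 `CCOC(=O)CCCCCOc1cccc(CN(C(=O)c2ccc(-c3cccc(OCC(C)C)c3)cc2)C(C)C)c1` and compound 3 `CCOC(=O)CCCCCOc1cccc(CN(C(=O)c2ccc(-c3cccc(OCC)c3)cc2)C(C)C)c1` share one core and differ only in the group on the outer aromatic ring. In an ADME assay on HepG2 cells (Homo sapiens) for cytotoxicity, read by CellTiter-Glo and resazurin assay, with a stated time of 72 h (a higher number here means that more compound is needed for the effect, a lower number that less compound is needed), compound 1 reaches only the limit of the assay, > 26000 nM. Compound 2 likewise gives only a limit in this assay, > 26000 nM. Compound 3 gives only a limit as well, > 22300 nM in this assay. Compound 3 thus stands at a limit, with nothing to rank it against. All three values are limits, as the limit of > 26000 nM in this assay, at which 2 of the 3 values shown sit, and the limit of > 22300 nM in this assay, at which 1 of the 3 values shown sits, record, so the steps a step that the two limits leave unreadable from compound 1 to compound 2, a step that the two limits leave unreadable from compound 1 to compound 3 and a step that the two limits leave unreadable from compound 2 to compound 3 cannot be sized. Compound 4 `CCOC(=O)CCCCCOc1cccc(CN(C(=O)c2ccc(-c3ccc4c(c3)OCCO4)cc2)C(C)C)c1` carries 2,3-dihydro-1,4-benzodioxin-6-yl in place of 3-ethoxyphenyl on an aromatic carbon. Going by the values given here, no measured step bears on this change with a readable size, so the step that the limit leaves unreadable from compound 3 to compound 4 is expected to stay unreadable in this assay, with no direction that can be stated. For compound 4 the estimate in this assay is 30000 nM, within 15000 nM to 80000 nM, and a limit is again the most likely report.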

Compound 4, half-maximal effective concentration: > 24400 nM
Compound 4 was reported as a limit; the forecaster's own chance of this, stated with the estimate: 85%; the middle value does not contradict the limit.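

In this assay compound 4 gives only a limit, > 24400 nM, so its steps from compound 1, compound 2 and compound 3 cannot be read. The compounds shown leave open where the half-maximal effect of any of the four lies, and whether the outer group changes it.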